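This account rests on a few compounds, and the source may have more. Where it says the series, first, only, none or still open, it means among the compounds named here.

Compound 1 `COc1ccc(Nc2cc3[nH]c(-c4cccc(C(F)(F)F)c4)nc3cn2)nc1` was measured in a physicochemical assay for solubility, using the shake flask method, in phosphate buffer, measured as kinetic solubility, with a stated time of 20 h, at pH 6.5; on this read-out lower numbers stand for lower solubility and higher numbers for higher solubility. In this assay compound 1 gives < 5000 nM, which is a limit of the assay and not a number. Compound 2 `Fc1ccc(-c2nc3cnc(Nc4ccc(C(F)(F)F)cn4)cc3[nH]2)cc1F` was measured in the same way. In this assay compound 2 gives < 5000 nM, again a limit rather than a number. Compound 1 therefore stands at the limit of < 5000 nM in this assay, at which 2 of the 2 values shown sit, and no ranking of the two can be drawn from this. For the measured compounds named here, no step between two measured compounds is known here.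

Compound 3 `NC(=O)c1ccc(Nc2cc3[nH]c(-c4cccc(C(F)(F)F)c4)nc3cn2)nc1` has not yet been measured in this assay. It differs from compound 1 by carbamoyl in place of methoxy on an aromatic carbon. With compound 1 itself at a limit, the size of any step cannot be anchored in measurement. The step of an at least 1.2-fold higher number from compound 1 to compound 3 (0.07 log units; that floor lies within the scatter) is an expectation only, pointing toward higher solubility if toward any change at all. Compound 3 is expected to give about 6000 nM in this assay, within a range from 1500 nM to 25000 nM.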

Compound 3, solubility: < 5000 nM
Compound 3: a limit, no number; the forecaster's own chance of this, stated with the estimate: 50%; middle value at least 1.2-fold (0.07 log units) away from the limit.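

With compound 1 and compound 3 both at a limit of the assay, the change from methoxy to carbamoyl cannot be read as a step in this assay. The compounds shown leave open how compound 1, compound 2 and compound 3 rank, as all share one limit: the limit of < 5000 nM in this assay, at which 3 of the 3 values shown sit.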